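Shortening the hydroxamate chain of compound 2

The source may report more compounds than this note shows. Statements on the series, on what has been measured and on what is new or still open speak of the compounds shown alone.

Of the compounds shown here, two have so far been measured in a functional assay on HeLa cells (Homo sapiens) for inhibition, read by MTT assay, with a stated time of 72 h (on this read-out higher numbers stand for weaker inhibition and lower numbers for stronger inhibition), and give the only footing here. Compound 1, with the structure `Nc1ncnc2c1c(-c1cnc3[nH]ccc3c1)nn2CCCCCCCCC(=O)NO`, gives 7470 nM in this assay. Compound 2, with the structure `Nc1nc2cc(-c3nn(CCCCCCCCCC(=O)NO)c4ncnc(N)c34)ccc2o1`, is reported in this assay only as a limit of > 50000 nM and not as a number. On these data alone, compound 2 therefore stands at the limit of > 50000 nM in this assay, at which 1 of the 2 values shown sits, and its true value is unknown beyond that bound. Compound 3, with the structure `Nc1nc2cc(-c3nn(CCCCCCC(=O)NO)c4ncnc(N)c34)ccc2o1`, is yet to be measured. Compound 3 differs from compound 2 in one place: hydroxycarbamoyl in place of 3-(hydroxycarbamoyl)propyl on a saturated chain carbon, six bonds along the chain from an aromatic nitrogen. Since compound 1 and compound 2 differ in both core and chain, their two values show only that one lies at a number and the other at a bound, and no step size between measured compounds is established. The step is expected to be an at least 1.6-fold lower number from compound 2 to compound 3 (0.22 log units; that floor lies within the scatter) towards stronger inhibition, though whether it exceeds the scatter is uncertain. Compound 3 is thus estimated to give about 30000 nM in this assay, within a range from 8000 nM to 60000 nM.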

Compound 3, half-maximal inhibitory concentration: 6410 nM
The estimate for compound 3 lay 4.7-fold (0.67 log units) above the measured number; measured number outside the range, below it.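

Among these compounds, on the shared core, hydroxycarbamoyl in place of 3-(hydroxycarbamoyl)propyl, on a saturated chain carbon six bonds along the chain from an aromatic nitrogen, gives the first step that can be read in this assay, namely an at least 7.8-fold lower number from compound 2 to compound 3 (0.89 log units; beyond the scatter), so at this position the shorter chain goes with stronger inhibition. This size is a floor, and the true step may be larger. Compound 2 is reported only as a limit and not as a number: the limit of > 50000 nM in this assay, at which 1 of the 3 values shown sits.

The compounds shown compare only these two chain lengths on this core, so it remains open how a chain of intermediate length, or one shorter than that of compound 3, would read. Also open, on these data alone, is whether a carboxylic acid in place of the hydroxycarbamoyl end would keep the inhibition seen for compound 3.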